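A 1H-pyrazol-1-yl group added to compound 2

The compounds below may be only part of what the source reports. "The series", "measured", "known", "first", "only" and "open" are said of these compounds alone.

Measured in a physicochemical assay for solubility, using the shake flask method, in simulated intestinal fluid, measured as kinetic solubility, with a stated time of 2 h, at 25 degrees C, at pH 6.5; a lower number here means a less soluble compound, a higher number a more soluble compound:
compound 1 `CCCOC(=O)c1nc(C)c2c(c1N)C(=O)N(Cc1ccccc1)C2=O`: < 5000 nM, a limit
compound 2 `Cc1noc(-c2nc(C)c3c(c2N)C(=O)N(Cc2ccccc2)C3=O)n1`: < 5000 nM, a limit

Compound 2 has no exact number: in this assay compound 2 is reported only as the limit < 5000 nM. Compound 3 `Cc1noc(-c2nc(C)c3c(c2N)C(=O)N(Cc2ccc(-n4cccn4)cc2)C3=O)n1` differs from compound 2 by one structural change: 1H-pyrazol-1-yl in place of hydrogen on an aromatic carbon. The new group sits on an aromatic carbon of a six-membered aromatic ring of carbon only, para to a large group.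

Among the compounds with values here, only one measured step is available, a step that the two limits leave unreadable from compound 1 to compound 2. It concerns another group, and its size cannot be read. The evidence amounts to the limit of < 5000 nM in this assay, at which 2 of the 2 values shown sit. No measured size or direction can therefore be carried over to the new change, and no step beyond the scatter is expected. Compound 3 is expected to be reported as a limit as well. The expected step is a step that the limit leaves unreadable from compound 2 to compound 3, an estimate resting on very little. For compound 3 the estimated value is 2000 nM, with an expected range from 400 nM to 5000 nM.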

Compound 3, solubility: < 5000 nM
Compound 3 gave a limit, no number; the forecaster's own chance of this, stated with the estimate: 85%; the middle value lies beyond the limit too.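

Within the data shown here, compound 2 and compound 3 are both reported only as limits in this assay, so no step between them can be read. The compounds shown leave open how soluble any of them actually is, and whether the 1H-pyrazol-1-yl group in place of hydrogen makes any difference to that read-out.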